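This account rests on a few compounds, and the source may have more. Where it says the series, first, only, none or still open, it means among the compounds named here.

Measured so far:
compound 3 `COc1cc(-c2nn(-c3cccc(NC(=O)Nc4cccc(C(F)(F)F)c4)c3)cc2-c2ccncc2)ccc1Cl`: 306 nM
compound 1 `O=C(Nc1cccc(-n2cc(-c3ccncc3)c(-c3ccc(Cl)c(O)c3)n2)c1)Nc1cccc(C(F)(F)F)c1`: 962 nM
compound 2 `COc1cc(-c2nn(-c3cccc(NC(=O)c4cccc(C(F)(F)F)c4)c3)cc2-c2ccncc2)ccc1Cl`: 1020 nM

In a functional assay on SF-295 cells (Homo sapiens) for inhibition, read by sulforhodamine B assay, with a stated time of 48 h (a higher number here means a weaker inhibitor of growth, a lower number a stronger inhibitor of growth), compound 3 gives the lowest of the three numbers, with both neighbours beyond the scatter: a 3.1-fold lower number from compound 1 to compound 3 (0.50 log units; beyond the scatter) and a 3.3-fold lower number from compound 2 to compound 3 (0.52 log units; beyond the scatter). Compound 4 `COc1cc(-c2nn(-c3cccc(NC(=O)Nc4ccc(Cl)c(C(F)(F)F)c4)c3)cc2-c2ccncc2)ccc1Cl` differs from compound 3 in one place: chloro in place of hydrogen on an aromatic carbon. Neither measured step touches this ring; one changed the oxygen on the other aryl ring, the other exchanged the amide for a urea. Among the measured compounds shown here, there is thus no direct precedent for adding chloro here, and a step of modest size at most is expected in this assay, in either direction or none beyond the scatter. Compound 4 is therefore estimated at 250 nM, within 100 nM to 800 nM, which would mean an expected 1.2-fold lower number from compound 3 to compound 4 (0.09 log units; within the scatter).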

Compound 4, concentration for 50% growth inhibition: 840 nM
For compound 4 the middle estimate is 3.4-fold (0.53 log units) below the measured one; the whole stated range lies below it.
By their numbers in this assay, from the lowest: compound 3; then compounds 4, 1 and 2 (each within the scatter of the next).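

In this assay, the ring carrying the trifluoromethyl group does not tolerate every addition: chloro on this aromatic carbon, ortho to the trifluoromethyl group, gives a 2.7-fold higher number from compound 3 to compound 4 (0.44 log units; beyond the scatter), a step of similar size to those seen at the other two changes. The advantage of compound 3 over the amide is then gone, with a 1.2-fold lower number from compound 2 to compound 4 (0.08 log units; within the scatter). Nothing measured here explains this step.

Going by these compounds, whether fluoro or an amine on this same carbon would behave as chloro does remains open. So does whether chloro would give a similar step on the amide compound 2.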